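A few compounds are considered here, and "the series" means these few. Any claim that something is new, unique, unknown or untested is made for them only; others in the source may bear on it.

The measured compounds in a functional assay on SW480 cells (Homo sapiens) for cytotoxicity, read by MTT assay, with a stated time of 48 h; on this read-out lower numbers stand for stronger inhibition and higher numbers for weaker inhibition:
compound 1 `O=c1ccoc2cc(OCc3cn(Cc4ccccc4)nn3)ccc12` gives 42900 nM
compound 2 `O=c1ccoc2cc(OCc3cn(Cc4ccc(Br)cc4)nn3)ccc12` gives 37500 nM
compound 3 `CC(C)(C)c1ccc(Cn2cc(COc3ccc4c(=O)ccoc4c3)nn2)cc1` gives 28800 nM

All three share the same core and differ only at one aromatic carbon of the six-membered aromatic ring of carbon only. Compound 3 sits among these numbers without separating from them: the step of a 1.5-fold lower number from compound 1 to compound 3 (0.17 log units; within the scatter) and the step of a 1.3-fold lower number from compound 2 to compound 3 (0.11 log units; within the scatter) are both within the scatter, as is the step of a 1.1-fold lower number from compound 1 to compound 2 (0.06 log units; within the scatter). On this read-out, then, hydrogen, bromo and tert-butyl at that position behave alike.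

Compound 4 `O=c1ccoc2cc(OCc3cn(Cc4ccc([N+](=O)[O-])cc4)nn3)ccc12` is not yet measured. It differs from compound 3 by nitro in place of tert-butyl on an aromatic carbon. Within the data shown here, none of the measured steps involves a nitro group, so no step bears directly on this change; what bears on it indirectly is that every exchange made so far at this carbon, a 1.1-fold lower number from compound 1 to compound 2 (0.06 log units; within the scatter), a 1.5-fold lower number from compound 1 to compound 3 (0.17 log units; within the scatter) and a 1.3-fold lower number from compound 2 to compound 3 (0.11 log units; within the scatter), stayed within the scatter. On that basis the expected step in this assay is a 1.2-fold higher number from compound 3 to compound 4 (0.07 log units; within the scatter), which is no change beyond the scatter. Compound 4 is therefore estimated at 34000 nM, with a range from 15000 nM to 75000 nM.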

Compound 4, half-maximal inhibitory concentration: 19300 nM
Beside the measured number, compound 4's estimate is 1.8-fold (0.25 log units) above it; low and high end bracket the measured number.
By their numbers in this assay, from the lowest: compounds 4, 3, 2 and 1 (each within the scatter of the next, the first and the last beyond it).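

In this assay, among these compounds, nitro is the first exchange at this aromatic carbon to pass beyond the scatter, and it does so only against hydrogen: a 2.2-fold lower number from compound 1 to compound 4 (0.35 log units; beyond the scatter) is a modest step, whereas a 1.9-fold lower number from compound 2 to compound 4 (0.29 log units; within the scatter) and a 1.5-fold lower number from compound 3 to compound 4 (0.17 log units; within the scatter) stay within the scatter. The position is therefore not wholly indifferent to what it carries, yet the effect is small, since each of the four compounds lies within the scatter of its neighbour in the order of values and only the two ends of that order, compound 4 and compound 1, separate. Nothing available here explains why nitro alone parts from hydrogen at this carbon.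

The compounds shown leave open whether an amine, a carboxylic acid or a methoxy group on this aromatic carbon would widen the gap from compound 1 or leave the number within the scatter. They also leave open whether the modest step from hydrogen to nitro would hold on another cell line, or with a longer chain in place of the single carbon that joins this ring to the triazole-bearing part of the shared core.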